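Shrinking the Saturated Ring on the Thioether Arm

The compounds below may be only part of what the source reports. "The series", "measured", "known", "first", "only" and "open" are said of these compounds alone.

Compound 1 `Cc1cc(Nc2cc(-c3ccccc3)[nH]n2)n2nc(SCC3CCCCC3)nc2n1` is measured in a functional assay on PC-9 cells (Homo sapiens) for inhibition, read by MTT assay, with a stated time of 72 h (a lower number here means a stronger inhibitor, a higher number a weaker inhibitor), only as an assay limit, > 50000 nM, because the reading sits at the limit of > 50000 nM in this assay, at which 1 of the 3 values shown sits. Compound 2 `Cc1cc(Nc2cc(-c3ccccc3)[nH]n2)n2nc(SCc3cccc(Br)c3)nc2n1` gives 8900 nM in this assay. Compound 3 `Cc1cc(Nc2cc(-c3ccccc3)[nH]n2)n2nc(SCc3csc4ccccc34)nc2n1` gives 4420 nM. The step of an at least 5.6-fold lower number from compound 1 to compound 2 (0.74 log units; beyond the scatter) and the step of an at least 11-fold lower number from compound 1 to compound 3 (1.05 log units; beyond the scatter) each exchange the cyclohexyl for an aromatic group; the step of a 2.0-fold lower number from compound 2 to compound 3 (0.30 log units; within the scatter) lies within the scatter.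

Compound 4 `Cc1cc(Nc2cc(-c3ccccc3)[nH]n2)n2nc(SCC3CC3)nc2n1` differs from compound 1 by cyclopropyl in place of cyclohexyl on a saturated chain carbon bound to a sulfur. Cyclopropyl is a smaller saturated ring rather than an aromatic one, and no measured step covers such an exchange. The measured gains from compound 1 followed entry of an aromatic group in an at least 5.6-fold lower number from compound 1 to compound 2 (0.74 log units; beyond the scatter) and an at least 11-fold lower number from compound 1 to compound 3 (1.05 log units; beyond the scatter), and no comparable gain is expected here. Compound 4 is expected to show a step that the limit leaves unreadable from compound 1 to compound 4, a step within the scatter. Compound 4 is estimated at 70000 nM, between 20000 nM and 200000 nM, and it is expected most likely to be reported again only as a limit.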

Compound 4, half-maximal inhibitory concentration: > 50000 nM
Compound 4 ended at the assay's limit (the forecaster's own chance of this, stated with the estimate: 70%); the middle value is on the limit's open side.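

In this assay compound 4, like compound 1, gives only a limit of the assay, so the step between them cannot be read, and changing the size of the saturated ring from cyclohexyl to cyclopropyl shows no readable effect: the limit of > 50000 nM in this assay, at which 2 of the 4 values shown sit.

Setting cyclopropyl in place of an aromatic group gives an at least 11-fold higher number from compound 3 to compound 4 (1.05 log units; beyond the scatter) and an at least 5.6-fold higher number from compound 2 to compound 4 (0.74 log units; beyond the scatter). Among the four compounds, readable values on the saturated chain carbon bound to a sulfur therefore come only with the two aromatic groups, now against two saturated rings of different size, and no compound shown goes against this.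

Still open, going by these compounds, is whether a plain phenyl on that carbon would be enough to give a readable value. Also open, on these data alone, is what an amine, a carboxylic acid or a longer chain would do at this position.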